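The source may report more compounds than this note shows. Statements on the series, on what has been measured and on what is new or still open speak of the compounds shown alone.

Measured so far in an ADME assay on CHO cells (Cricetulus griseus) for inhibition, read by MTT assay; a lower number here means a stronger inhibitor, a higher number a weaker inhibitor:
- compound 1 `CC(C)(C)NCc1cc(Cl)cc(Nc2nc3ccccc3n2Cc2ccc(C(F)(F)F)cc2)c1O`: 36300 nM
- compound 2 `CCN(CC)Cc1ccc(C)c(Nc2nc3ccccc3n2Cc2ccc(C#N)cc2)c1O`: > 50000 nM, a limit of the assay
- compound 3 `CC(C)(C)NCc1cc(Cl)cc(Nc2nc3ccccc3[nH]2)c1O`: > 50000 nM, a limit of the assay

Compound 3 has no number of its own, only the limit > 50000 nM. Compound 2 also reads only as a limit. Among the compounds with values here, the series so far therefore shows (the limit of > 50000 nM in this assay, at which 2 of the 3 values shown sit).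

The next compound, compound 4 `CC(C)(C)NCc1cc(C(C)(C)C)cc(Nc2nc3ccccc3[nH]2)c1O`, keeps the rest of compound 3 and carries tert-butyl in place of chloro on an aromatic carbon, para to a hydroxy group: tert-butyl in place of chloro on an aromatic carbon.

Within the data shown here, only one measured step is available, an at least 1.3-fold higher number from compound 1 to compound 3 (0.13 log units; that floor lies within the scatter), and it involves hydrogen in place of 4-(trifluoromethyl)benzyl on an aromatic nitrogen. Among the measured compounds shown here, it does not touch the chloro group, and no measured compound carries tert-butyl on this carbon, so the data give no size for this change. No step beyond the scatter is expected in this assay. Compound 4 is expected to stay close to the limit, and it may read only as a limit. A number near that of compound 1, at 36300 nM, would also fit this expectation. The estimated step is an at least 1.1-fold lower number from compound 3 to compound 4 (0.04 log units; that floor lies within the scatter). For compound 4 the estimated value is 45000 nM, with an expected range from 18000 nM to 80000 nM.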

Compound 4, half-maximal inhibitory concentration: 30500 nM
Compound 4: middle estimate off by 1.5-fold (0.17 log units), on the high side; the range from low to high includes it.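

In this assay, within the data shown here, the step at this carbon, para to a hydroxy group, is an at least 1.6-fold lower number from compound 3 to compound 4 (0.21 log units; that floor lies within the scatter), and it gives the series its only reading of a change at this position. Of the two compounds with a free hydrogen on the aromatic nitrogen, compound 4 is the one that reads as a number, so tert-butyl on this carbon is compatible with a measurable value in this assay, although the step does not show that the swap from chloro matters. Compound 3 reads only as a limit, > 50000 nM, so the true size of the step stays unknown: the limit of > 50000 nM in this assay, at which 2 of the 4 values shown sit.

The compounds shown leave open how other groups on this carbon, such as methyl, bromo, methoxy or a carboxylic acid, would read against chloro and tert-butyl. They also leave open whether tert-butyl here would behave the same way with the 4-(trifluoromethyl)benzyl group of compound 1 on the aromatic nitrogen, and how far below the limit any compound of this kind can go.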